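A few compounds are considered here, and "the series" means these few. Any claim that something is new, unique, unknown or untested is made for them only; others in the source may bear on it.

Compounds measured in a functional assay on HEK293 cells for agonist activity at Bile acid receptor (Homo sapiens), read by a luciferase reporter; on this read-out higher numbers stand for larger maximal responses and lower numbers for smaller maximal responses:
- compound 1, `Cc1cc(OCc2c(-c3c(Cl)cccc3Cl)noc2C(C)C)nc2ccccc12`: 68%
- compound 2, `CC(C)c1onc(-c2c(Cl)cccc2Cl)c1COc1ccc(N(C)Cc2cccc(C(=O)O)c2)c(C(F)(F)F)n1`: 58%
- compound 3, `CN(Cc1cccc(C(=O)O)c1)c1ccc(OCc2c(-c3c(Cl)cccc3Cl)noc2C2CC2)nc1C(F)(F)F`: 43%

Compound 3 gives the lowest of these three numbers; its nearest neighbour is compound 2, and the step of a number 15 percentage points lower from compound 2 to compound 3 (beyond the scatter) came with a cyclopropyl in place of an isopropyl on an aromatic carbon. Compound 4, `CC(Nc1ccc(C(=O)O)cc1)c1ccc(OCc2c(-c3c(Cl)cccc3Cl)noc2C2CC2)nc1C(F)(F)F`, differs from compound 3 by 1-((4-carboxyphenyl)amino)ethyl in place of (3-carboxybenzyl)(methyl)amino on an aromatic carbon. Within the data shown here, no measured step touches this kind of change, which rearranges the same atoms; the only known step concerns a different part of the molecule, so it gives no direction. Compound 4 is therefore expected to stay close to compound 3, with a number 2 percentage points higher from compound 3 to compound 4 (within the scatter) and an estimated value of 45%, ranging from 25% to 70%.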

Compound 4, largest response reached (reported as efficacy), in percent of the reference or control that the assay uses: 49%
For compound 4 the middle estimate is 4 percentage points below the measured one; the range from low to high includes it.
By their numbers in this assay, from the lowest: compounds 3, 4, 2 and 1 (each within the scatter of the next, the first and the last beyond it).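

At this position, ortho to a trifluoromethyl group, the 1-((4-carboxyphenyl)amino)ethyl group replaces (3-carboxybenzyl)(methyl)amino with a number 6 percentage points higher from compound 3 to compound 4 (within the scatter) in this assay. The same atoms can thus be joined differently, with the carboxyphenyl ring attached through another chain, without a change beyond the scatter. No measurement available here accounts for this result.

As far as these compounds go, whether the response needs the carboxylic acid remains open, as a methyl ester or a primary amide at that spot would test. From the compounds shown here alone, it is also open whether a shorter link, such as a single methylene, would give a similar response.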